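Oxabicyclic amide acids: chain extension at the butyl amide

The compounds below may be only part of what the source reports. "The series", "measured", "known", "first", "only" and "open" are said of these compounds alone.

Of the compounds shown here, three share a core and have been measured in an ADME assay on A2780 cells (Homo sapiens) for cytotoxicity, read by MTT assay, with a stated time of 72 h; a lower number here means a stronger inhibitor of growth, a higher number a weaker inhibitor of growth. Compound 1, `CCCCNC(=O)C1C(C(=O)O)[C@@H]2CC[C@H]1O2`, carries a butyl amide and gives 10000 nM in this assay. Compound 2, `Cn1ccc2cc(CNC(=O)C3C(C(=O)O)[C@@H]4CC[C@H]3O4)ccc21`, carries an indolylmethyl amide and gives 10000 nM. Compound 3, `O=C(O)C1C(C(=O)Nc2ccc(CO)cc2)[C@H]2CC[C@@H]1O2`, carries an anilide and gives 10000 nM. At the digits recorded, compound 1 stands level with compounds 2 and 3; the nearest is compound 2 and the furthest compound 3, and neither gap goes beyond the usual scatter. Across the three amides no separation in this assay is seen.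

Compound 4, `CCCCCCCCNC(=O)C1C(C(=O)O)[C@@H]2CC[C@H]1O2`, has not yet been measured. It differs from compound 1 by butyl in place of hydrogen on a saturated chain carbon, four bonds along the chain from an amide-type nitrogen. Among the measured compounds shown here, no measured pair differs in this way, so nothing seen so far predicts the size of this step. Since the three amides already examined give the same reading in this assay, the step from a butyl to an octyl chain is expected to stay within the scatter, without a clear direction.

The expected step in this assay is no change at the digits printed from compound 1 to compound 4 (within the scatter). For compound 4 the estimate in this assay is 10000 nM, with a range from 4000 nM to 25000 nM.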

Compound 4, concentration for 50% growth inhibition: 10000 nM
The estimate for compound 4 equals the measured number at the digits printed; the measured number falls inside the stated range.
By their numbers in this assay, from the lowest: compounds 1, 2, 3 and 4 (each within the scatter of the next).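

In this assay, the first step read at this position gives no change at the digits printed from compound 1 to compound 4 (within the scatter), so butyl in place of hydrogen on a saturated chain carbon, four bonds along the chain from an amide-type nitrogen, brings no separation from the butyl amide. The earlier compounds shown here could not show this, as none of them formed a pair differing in one place, and the series held no step at all. With compound 4 at 10000 nM, the octyl amide reads level with the butyl amide of compound 1, so this chain extension gives no handle on growth inhibition in these cells; no measurement shown offers an explanation for this flat reading.

Still open, going by these compounds, is whether any group at this chain end can move the reading, for example a terminal amine, a terminal carboxylic acid, a terminal phenyl ring or a chain longer than octyl. Also open, on these data alone, is whether the same extension would read the same way on a core in which the free carboxylic acid is replaced by a methyl ester or a primary amide.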